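Methyl for chloro on the sulfonyl aryl ring

The compounds below may be only part of what the source reports. "The series", "measured", "known", "first", "only" and "open" are said of these compounds alone.

Three compounds share one core and differ only in the group on an aromatic nitrogen. Compound 1 `CC(C)Cn1c(N)nc2c1c(=O)n(CC1CC1)c(=O)n2CC1CC1` gives 3500 nM in an assay (brain) for binding affinity to adenosine receptor A1 (Rattus norvegicus) (on this read-out higher numbers stand for weaker inhibition and lower numbers for stronger inhibition), compound 2 `Nc1nc2c(c(=O)n(CC3CC3)c(=O)n2CC2CC2)n1Cc1ccccc1` gives 2800 nM, and compound 3 `Nc1nc2c(c(=O)n(CC3CC3)c(=O)n2CC2CC2)n1S(=O)(=O)c1ccc(Cl)cc1` gives 4100 nM. Compound 3 carries the highest of the three numbers, but all three stand close: a 1.2-fold higher number from compound 1 to compound 3 (0.07 log units; within the scatter) and a 1.5-fold higher number from compound 2 to compound 3 (0.17 log units; within the scatter) are both within the scatter, as is a 1.3-fold lower number from compound 1 to compound 2 (0.10 log units; within the scatter). Compound 4 `Cc1ccc(S(=O)(=O)n2c(N)nc3c2c(=O)n(CC2CC2)c(=O)n3CC2CC2)cc1` differs from compound 3 by methyl in place of chloro on an aromatic carbon. Going by the values given here, no measured step alters a group on this ring, so none bears directly on the change; the three steps that exist all concern the group on the aromatic nitrogen and none of them moved the number beyond the scatter. Compound 4 is therefore expected to stay close to compound 3, with a 1.0-fold lower number from compound 3 to compound 4 (0.01 log units; within the scatter) as the estimated step, and its estimated value in this assay is 4000 nM with a range from 1500 nM to 11000 nM.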

Compound 4, half-maximal inhibitory concentration: 3800 nM
Beside the measured number, compound 4's estimate is 1.1-fold (0.02 log units) above it, and the stated range covers the measured number.
By their numbers in this assay, from the lowest: compounds 2, 1, 4 and 3 (each within the scatter of the next).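

In this assay, going by these compounds alone, the exchange of methyl for chloro on the aromatic carbon para to a large group gives a 1.1-fold lower number from compound 3 to compound 4 (0.03 log units; within the scatter), the first measured change on the sulfonyl aryl ring itself, and these two groups do not separate at this position. The (4-methylphenyl)sulfonyl group also stays level with the other groups on the aromatic nitrogen, with a 1.4-fold higher number from compound 2 to compound 4 (0.13 log units; within the scatter) against benzyl and a 1.1-fold higher number from compound 1 to compound 4 (0.04 log units; within the scatter) against isobutyl, so none of the changes at that nitrogen among these compounds moves the number beyond the scatter. Nothing available explains why these exchanges leave the number in place.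

On these data alone, whether an amine or a carboxylic acid on this ring carbon would move the number beyond the scatter remains open. Also open, as far as these compounds go, is how a longer alkyl chain on the sulfonyl group, in place of the aryl ring, would compare.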